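A few compounds are considered here, and "the series" means these few. Any claim that something is new, unique, unknown or untested is made for them only; others in the source may bear on it.

Measured compounds in an ADME assay on HepG2 cells (Homo sapiens) for cytotoxicity, with a stated time of 3 days; on this read-out higher numbers stand for lower toxicity in this test and lower numbers for higher toxicity in this test:
- Compound 1 `CC(Sc1nnc(-c2ccncc2)s1)C(=O)Nc1ccccc1Cl` gives > 50000 nM, a limit of the assay.
- Compound 2 `CC(Sc1nnc(-c2ccncc2)s1)C(=O)Nc1c(Cl)cccc1Cl` gives > 50000 nM, a limit of the assay.
- Compound 3 `O=C(CCSc1nnc(-c2ccncc2)s1)Nc1ccccc1` gives > 50000 nM, a limit of the assay.

Compound 3 stands where every compound of this series stands so far: only a limit is known for it in this assay, and the two further values shown are limits as well (the limit of > 50000 nM in this assay, at which 3 of the 3 values shown sit). Within the data shown here, no compound has a readable number. Among the measured compounds shown here, the one measured step, a step that the two limits leave unreadable from compound 1 to compound 2, cannot be read because the limit of > 50000 nM in this assay, at which 3 of the 3 values shown sit, places both of its ends at the assay limit; it concerns chloro in place of hydrogen on an aromatic carbon, which is the nearest relative of the change considered here.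

Compound 4 `O=C(CCSc1nnc(-c2ccncc2)s1)Nc1ccc(Cl)cc1Cl` differs from compound 3 by 2,4-dichlorophenyl in place of phenyl on an amide-type nitrogen. For the measured compounds named here, no measured step gives a size for such a change; the only step that bears on it is unreadable. Going by the values given here, nothing among the measured values therefore points to a step beyond the scatter in either direction in this assay.

Compound 4 is accordingly expected to sit at the limit as well, with an estimated value of 50000 nM, in the range 20000 nM to 100000 nM. This estimate means an expected step of a number no higher from compound 3 to compound 4 (the limit leaves the size open), that is, no change beyond the scatter.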

Compound 4, half-maximal cytotoxic concentration: > 50000 nM
Compound 4: only a limit was reported (the forecaster's own chance of this, stated with the estimate: 75%); the middle value lies on the limit itself.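

No step can be read between compound 3 and compound 4 in this assay, as both ends are limits of the assay: the limit of > 50000 nM in this assay, at which 4 of the 4 values shown sit.

The compounds shown leave open how large the effect of 2,4-dichlorophenyl in place of phenyl on an amide-type nitrogen is, and whether any compound of this series gives a readable number in this assay.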